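The source may hold more compounds than are shown below. What is called first, only, known or untested is meant among the compounds shown, and "the series" means these compounds.

Measured compounds:
- compound 1, `COc1ccc(C(=O)c2cc(OC)c(OC)c(OC)c2)cc1NC(=O)/C=C/c1cc(OC)c(OC)c(OC)c1`: 3100 nM
- compound 2, `COc1ccc(C(=O)c2cc(OC)c(OC)c(OC)c2)cc1NC(=O)/C=C/c1ccc(F)c(F)c1`: 4200 nM
- compound 3, `COc1cc(C(=O)c2cc(OC)c(OC)c(OC)c2)cc(NC(=O)/C=C/c2cc(OC)c(OC)c(OC)c2)c1OC`: 3100 nM

All three were tested in a functional assay on HT-29 cells (Homo sapiens) for cytotoxicity, read by MTT assay, with a stated time of 72 h; on this read-out higher numbers stand for weaker inhibition and lower numbers for stronger inhibition. Compound 3 stands level with compound 1 at the digits shown, and together they hold the lowest numbers of the three; its nearest neighbour is compound 1, no change at the digits printed from compound 1 to compound 3 (within the scatter), and its furthest is compound 2, a 1.4-fold higher number from compound 1 to compound 2 (0.13 log units; within the scatter), both within the scatter.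

Compound 4, `COc1ccc(/C=C/C(=O)Nc2cc(C(=O)c3cc(OC)c(OC)c(OC)c3)cc(OC)c2OC)cc1OC`, has not yet been measured. It differs from compound 3 in one place: hydrogen in place of methoxy on an aromatic carbon.

Within the data shown here, two measured steps bear on this change. The step from compound 1 to compound 2, a 1.4-fold higher number from compound 1 to compound 2 (0.13 log units; within the scatter), swaps the whole 3,4,5-trimethoxyphenyl group on the double-bonded chain carbon for a different ring and stays within the scatter. The step from compound 1 to compound 3, no change at the digits printed from compound 1 to compound 3 (within the scatter), adds a methoxy on the core and also stays within the scatter. Neither step points to a shift beyond the scatter from trimming one methoxy. Compound 4 is therefore expected to show a 1.1-fold higher number from compound 3 to compound 4 (0.05 log units; within the scatter) in this assay, with an estimated value of 3500 nM, between 1500 nM and 8000 nM.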

Compound 4, half-maximal inhibitory concentration: 2300 nM
Beside the measured number, compound 4's estimate is 1.5-fold (0.18 log units) above it; low and high end bracket the measured number.
By their numbers in this assay, from the lowest: compounds 4, 1, 3 and 2 (each within the scatter of the next).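

In this assay, among these compounds, going from the 3,4,5-trimethoxyphenyl group to the 3,4-dimethoxyphenyl group gives a 1.3-fold lower number from compound 3 to compound 4 (0.13 log units; within the scatter) and so tests this single methoxy directly for the first time. The earlier steps shown here swapped the whole ring or added a methoxy on the core, whereas this one shows that hydrogen can stand in place of one methoxy on this ring, on an aromatic carbon ortho to a methoxy group, without moving the number beyond the scatter. No measurement on hand gives a reason for this result.

Among the compounds shown, only methoxy and hydrogen occupy this position, so it remains open whether an amine or a carboxylic acid there would leave the number within the scatter. Also open, from the compounds shown here alone, is whether the same change would hold on the core of compound 1.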